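The source may hold more compounds than are shown below. What is called first, only, known or untested is meant among the compounds shown, and "the series" means these compounds.

Measured compounds:
compound 1 `COc1cc2ncnc(Nc3ccc(F)cc3)c2cc1OCCCCC(=O)Nc1ccc(S(N)(=O)=O)cc1` — > 40000 nM
compound 2 `COc1cc2ncnc(Nc3cccc(C)c3)c2cc1OCCCCC(=O)Nc1ccc(S(N)(=O)=O)cc1` — 32100 nM
compound 3 `NS(=O)(=O)c1ccc(NC(=S)Nc2ccc3ncnc(Nc4ccc(F)c(Cl)c4)c3c2)cc1` — 15800 nM

In a functional assay on NCI-H1975 cells (Homo sapiens) for antiproliferative activity, read by MTT assay, with a stated time of 72 h (on this read-out higher numbers stand for weaker inhibition and lower numbers for stronger inhibition), compound 1 reaches only a limit, > 40000 nM. Compound 2 gives 32100 nM and compound 3 gives 15800 nM, the lowest of the two numbers, with compound 2 next at a gap beyond the scatter. Among the compounds with values here, the one single-point step, an at least 1.2-fold lower number from compound 1 to compound 2 (0.09 log units; that floor lies within the scatter), is a change on the same nitrogen but in the amide series and stays within the scatter.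

Compound 4 `NS(=O)(=O)c1ccc(NC(=S)Nc2ccc3ncnc(Nc4cccc(Br)c4)c3c2)cc1` differs from compound 3 by 3-bromophenyl in place of 3-chloro-4-fluorophenyl on a nitrogen on an aromatic ring. Within the data shown here, no measured step bears directly on an aryl change in the thiourea series; the only aryl step seen was small. A change of about a 1.1-fold lower number from compound 3 to compound 4 (0.02 log units; within the scatter) is expected, no direction being favoured. Compound 4 is estimated at 15000 nM in this assay, between 5000 nM and 40000 nM.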

Compound 4, half-maximal inhibitory concentration: 11000 nM
The estimate for compound 4 lay 1.4-fold (0.13 log units) above the measured number; the range from low to high includes it.
By their numbers in this assay, from the lowest: compounds 4 and 3 (each within the scatter of the next); then compound 2. At a limit, above all of these: compound 1.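

In this assay, the thiourea series now has a step at this position: a 1.4-fold lower number from compound 3 to compound 4 (0.16 log units; within the scatter), so 3-bromophenyl and 3-chloro-4-fluorophenyl on a nitrogen on an aromatic ring cannot be told apart here. Exchanging one chlorine and one fluorine for one bromine therefore leaves the read-out within the scatter. Nothing shown accounts for this result.

As far as these compounds go, it remains open whether any substituent at this position moves the number in the thiourea series. A phenyl bearing an amine or a carboxylic acid would test that more sharply than another halogen.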